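The compounds below may be only part of what the source reports. "The series", "measured", "known", "first", "only" and "open" are said of these compounds alone.

Measured compounds:
Compound 1 `CCOC(=O)C1=Cc2ccccc2OC1(OCc1cn(CC(=O)Nc2cccc(F)c2)nn1)C(F)(F)F`. In a functional assay on A549 cells (Homo sapiens) for inhibition, read by MTT assay, with a stated time of 24 h (on this read-out higher numbers stand for weaker inhibition and lower numbers for stronger inhibition), compound 1 gives only a limit, > 150000 nM.
Compound 2 `CCCCCCCCn1cc(COC2(C(F)(F)F)Oc3ccccc3C=C2C(=O)OCC)nn1`. In this assay compound 2 likewise gives only a limit, > 150000 nM.
Compound 3 `CCOC(=O)C1=Cc2ccccc2OC1(OCc1cn(-c2ccc(F)c(Cl)c2)nn1)C(F)(F)F`. In this assay compound 3 gives 26300 nM.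

For the measured compounds named here, compound 3 thus holds the only actual number here; the other two values are limits, namely (the limit of > 150000 nM in this assay, at which 2 of the 3 values shown sit). The steps onto compound 3 read an at least 5.7-fold lower number from compound 1 to compound 3 (0.75 log units; beyond the scatter) and an at least 5.7-fold lower number from compound 2 to compound 3 (0.75 log units; beyond the scatter), both at least modest, and both swap a chain-bound or carbamoyl-bearing group for an aryl group on the aromatic nitrogen.

Compound 4 `CCOC(=O)C1=Cc2ccccc2OC1(OCc1cn(-c2ccc([N+](=O)[O-])cc2)nn1)C(F)(F)F` is not yet measured. Its change from compound 3 is 4-nitrophenyl in place of 3-chloro-4-fluorophenyl on an aromatic nitrogen. Going by the values given here, this is an aryl-for-aryl swap at the same position, and no measured step here compares two aryl groups, so neither step onto compound 3 bears on it directly. Without such a comparison, no step beyond the scatter is expected in this assay for compound 4. Compound 4 is therefore estimated at 30000 nM, with a range of 8000 nM to 120000 nM, meaning an expected step of a 1.1-fold higher number from compound 3 to compound 4 (0.06 log units; within the scatter).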

Compound 4, half-maximal inhibitory concentration: > 150000 nM
Compound 4: no number, only a limit (the forecaster's own chance of this, stated with the estimate: 20%); at least 5.0-fold (0.69 log units) between middle value and limit.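

In this assay, for the compounds shown here, placing 4-nitrophenyl in place of 3-chloro-4-fluorophenyl on the aromatic nitrogen gives an at least 5.7-fold higher number from compound 3 to compound 4 (0.75 log units; beyond the scatter), the first comparison here of two aryl groups at this position. Going by these compounds alone, an aryl group at this position is therefore not enough by itself to give a measurable number, and compound 3 remains the only compound with one. The steps from compound 1 to compound 4 and from compound 2 to compound 4 cannot be read, as all three compounds sit at the same limit: the limit of > 150000 nM in this assay, at which 3 of the 4 values shown sit.

The compounds shown leave open which part of the 3-chloro-4-fluorophenyl group matters. A phenyl group carrying only the chlorine or only the fluorine, or an amine in place of the nitro group, could fall nearer either compound 3 or compound 4.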